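The source may report more compounds than this note shows. Statements on the series, on what has been measured and on what is new or still open speak of the compounds shown alone.

Three compounds sit on a shared core. Compound 1 `C[C@H](Nc1nc(N)nc(N)c1C#N)c1cc2ccc(F)cn2c(=O)c1-c1ccccc1` is the only one with a result: in an ADME assay on microsomes from liver (Rattus norvegicus), read by LC-MS, using NADPH, with a stated time of 30 min, tested at 1 uM (on this read-out higher numbers stand for a more stable compound and lower numbers for a less stable compound), compound 1 gives 88%, which places it among the more stable compounds on this read-out. Compound 2 `Cc1c([C@H](C)Nc2ncnc(N)c2C#N)c(-c2ccc(F)cc2)c2ccc(F)cn2c1=O` carries a methyl group and a 4-fluorophenyl group on the core, but in this assay compound 2 gives "not determined" (no result reported), so compound 2 cannot be placed on the scale at all. Compound 3 `C[C@H](Nc1ncnc(N)c1C#N)c1c(C2CC2)c(=O)n2cc(F)ccc2c1-c1ccc(F)cc1` differs from compound 2 in one place: cyclopropyl in place of methyl on an aromatic carbon. Within the data shown here, with no measured step available for this change, the expectation rests on the single result for compound 1 and on the small size of the alteration. For compound 3 in this assay, a shift no larger than the usual scatter is expected relative to a compound of this family, and the value for compound 3 is estimated at 75%, within a range of 45% to 95%.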

Compound 3, percent of the compound remaining: 1%
Compound 3: the middle estimate sits 74 percentage points above what was measured; measured number below the stated range.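

In this assay, among these compounds, compound 2 gives "not determined" (no result reported), so no step from compound 2 to compound 3 can be read. Nothing shown explains the result for compound 3. As far as these compounds go, whether swapping methyl for cyclopropyl changes stability in this family stays open.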